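This account rests on a few compounds, and the source may have more. Where it says the series, first, only, none or still open, it means among the compounds named here.

Measured in a physicochemical assay for solubility, read by HPLC, with a stated time of 24 h (on this read-out higher numbers stand for higher solubility and lower numbers for lower solubility), each entry being a limit and not a number:

Compound 1 `O=C(c1ccccc1)c1cccc(/C=c2\[nH]c(=O)/c(=C/c3ccccn3)[nH]c2=O)c1`: < 0.1 ug/mL
Compound 2 `CC(C)(C)c1[nH]cnc1/C=c1\[nH]c(=O)/c(=C/c2cccc(C(=O)N3CCCCC3)c2)[nH]c1=O`: < 0.1 ug/mL
Compound 3 `CC(C)(C)c1[nH]cnc1/C=c1\[nH]c(=O)/c(=C/c2cccc(C(=O)c3ccco3)c2)[nH]c1=O`: < 0.1 ug/mL

Compound 2 therefore offers a limit as its starting point, and the other two compounds share it: the limit of < 0.1 ug/mL in this assay, at which 3 of the 3 values shown sit. The step to be followed leads to compound 4 `CC(C)(C)c1[nH]cnc1/C=c1\[nH]c(=O)/c(=C/c2cccc(C(=O)c3ccoc3)c2)[nH]c1=O`, which carries furan-3-yl in place of piperidin-1-yl on a carbonyl carbon. For the measured compounds named here, the one measured step that bears on this change is a step that the two limits leave unreadable from compound 2 to compound 3, which puts furan-2-yl in place of piperidin-1-yl on a carbonyl carbon. It gives neither a size nor a direction, so no step beyond the scatter is expected in this assay. The estimate for the change is a step that the limit leaves unreadable from compound 2 to compound 4, with no direction expected. Another reading that gives only a limit is the likeliest outcome. For compound 4 the expected value is 0.07 ug/mL, with an estimated range from 0.02 ug/mL to 0.2 ug/mL.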

Compound 4, solubility: < 0.1 ug/mL
Compound 4: only a limit was reported; the forecaster's own chance of this, stated with the estimate: 85%; the middle value lies beyond the limit too.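

No step among compound 2, compound 3 and compound 4 can be read in this assay, and all the compounds shown share one limit: the limit of < 0.1 ug/mL in this assay, at which 4 of the 4 values shown sit.

The compounds shown leave open whether piperidin-1-yl, furan-2-yl and furan-3-yl on a carbonyl carbon differ at all in this assay.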